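The compounds below may be only part of what the source reports. "The series", "measured", "known", "first", "only" and "open" are said of these compounds alone.

Two compounds that share one core and differ in a single place have been measured. Compound 1 `O=C(Nc1cccc(-n2cc(-c3ccncc3)c(-c3cc(O)cc(Cl)c3)n2)c1)Nc1ccc(Cl)c(C(F)(F)F)c1` and compound 2 `COc1cc(Cl)cc(-c2nn(-c3cccc(NC(=O)Nc4ccc(Cl)c(C(F)(F)F)c4)c3)cc2-c2ccncc2)c1` were both tested in a functional assay on HCC 2998 cells (Homo sapiens) for inhibition, read by sulforhodamine B assay, with a stated time of 48 h, tested at 0.01 uM; on this read-out lower numbers stand for a stronger effect and higher numbers for a weaker effect at the one concentration tested. In this assay compound 1 gives 97%, and compound 2 gives 95%. Among the compounds with values here, the only step between them, a number 2 percentage points lower from compound 1 to compound 2 (within the scatter), is methyl in place of hydrogen on an oxygen on an aromatic ring, and it lies within the scatter, so compound 2 stands alongside compound 1 rather than apart from it.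

Compound 3 `COc1cc(Cl)cc(-c2nn(-c3cccc(NC(=O)c4cccc(C(F)(F)F)c4)c3)cc2-c2ccncc2)c1` has not yet been measured. It differs from compound 2 as follows: 3-(trifluoromethyl)phenyl in place of (4-chloro-3-(trifluoromethyl)phenyl)amino on a carbonyl carbon. Within the data shown here, this change has no counterpart among the measured steps; the one step seen so far touched a different part of the molecule and was small. These numbers therefore give no basis for expecting a shift beyond the scatter in this assay, and compound 3 is expected to give about 96%, within a range of 85% to 105%, which amounts to an expected step of a number 1 percentage points higher from compound 2 to compound 3 (within the scatter).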

Compound 3, a percentage reported as activity, at one concentration (the size of the read-out at that concentration, not a potency): 108%
Compound 3: middle estimate off by 12 percentage points, on the low side; the measured number lies above the stated range.
By their numbers in this assay, from the lowest: compounds 2 and 1 (each within the scatter of the next); then compound 3.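

The earlier step, on the oxygen of the aromatic ring, stayed within the scatter, so it showed no place where a change registers. The group on the carbonyl carbon is such a place: in this assay, replacing (4-chloro-3-(trifluoromethyl)phenyl)amino with 3-(trifluoromethyl)phenyl gives a number 13 percentage points higher from compound 2 to compound 3 (beyond the scatter) and, since higher numbers mean a weaker effect on this read-out, compound 3 does less than compound 2 at the one concentration tested. This is a single modest step on a single pair of compounds, and no measurement offered here accounts for it.

The swap alters two things at once, as the amino nitrogen and the chlorine both leave, so the step cannot be assigned to either one; 3-(trifluoromethyl)phenylamino or 4-chloro-3-(trifluoromethyl)phenyl on the same carbonyl carbon would pull the two apart. Also open, as far as these compounds go, is how quite different groups at this carbonyl carbon, such as a simple alkyl amine or a longer alkyl chain, would behave, and whether the step would hold at other concentrations.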